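Adding a Second Methoxy Group: Compound 3 to Compound 4

The source may report more compounds than this note shows. Statements on the series, on what has been measured and on what is new or still open speak of the compounds shown alone.

Compound 1 `O=C1C=COC(/C=C/c2ccccc2)C1` and compound 2 `COc1ccc(/C=C/C2CC(=O)C=CO2)cc1` differ by methoxy in place of hydrogen on an aromatic carbon. In a functional assay on MCF7 cells (Homo sapiens) for inhibition, read by sulforhodamine B assay, with a stated time of 48 h (a lower number here means a stronger inhibitor of growth, a higher number a weaker inhibitor of growth), compound 1 gives 153 uM and compound 2 gives 156 uM; this is a 1.0-fold higher number from compound 1 to compound 2 (0.01 log units; within the scatter). Compound 3 `COc1ccc(/C=C/c2cc(=O)cco2)cc1` rests on a different core, and the difference between the two cores is not broken down here. In this assay compound 3 gives 396 uM. Compound 4 `COc1ccc(/C=C/c2cc(=O)cco2)cc1OC` differs from compound 3 by methoxy in place of hydrogen on an aromatic carbon. This is the same kind of change as from compound 1 to compound 2, though the place differs: para to a group of 9 heavy atoms in one case, ortho to a methoxy group and meta to a group of 9 heavy atoms in the other. Because a 1.0-fold higher number from compound 1 to compound 2 (0.01 log units; within the scatter) stayed within the scatter, compound 4 is expected to show a step of a 1.0-fold higher number from compound 3 to compound 4 (0.00 log units; within the scatter). Compound 4 is estimated at 400 uM, between 200 uM and 800 uM.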

Compound 4, concentration for growth inhibition (reported as GI): 954 uM
For compound 4 the middle estimate is 2.4-fold (0.38 log units) below the measured one, outside the stated range (above it).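

In this assay the added methoxy group gives a 2.4-fold higher number from compound 3 to compound 4 (0.38 log units; beyond the scatter) and leaves compound 4 a weaker inhibitor of growth than compound 3. Set beside the earlier step, the result on the two cores cannot be told apart: the same change on two cores in this assay, a 1.0-fold higher number (0.01 log units; within the scatter) from compound 1 to compound 2 and a 2.4-fold higher number (0.38 log units; beyond the scatter) from compound 3 to compound 4, 2.4-fold (0.37 log units) apart, within the scatter of two such steps. Within the data shown here, this does not prove that the change carries over unaltered: each core offers only one pair, and the methoxy group sits at a different place in each, so any effect of the core cannot be separated from that of the place.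

The compounds shown leave open whether a different group at the same place, such as a hydroxyl or a chlorine, would act alike on both cores. They also leave open how the methoxy group would act at the same place on both cores.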